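The source may report more compounds than this note shows. Statements on the series, on what has been measured and on what is new or still open speak of the compounds shown alone.

Measured compounds:
compound 1, `OC[C@]1(c2cccc(F)c2)NC[C@H](O)[C@H]1O` — 0%
compound 2, `COc1cccc([C@@]2(CO)NC[C@H](O)[C@H]2O)c1` — 0%

Both compounds share the same core and differ only in the group on the aromatic ring. In an assay on isolated protein for inhibition of alpha-mannosidase (Canavalia ensiformis), tested at 1000 uM (on this read-out higher numbers stand for more inhibition at the one concentration tested (going by the name of the read-out) and lower numbers for less inhibition), compound 1 gives 0% and compound 2 gives 0%. Among the compounds with values here, the one measured step, no change at the digits printed from compound 1 to compound 2 (within the scatter), shows that exchanging the aromatic substituent left the read-out unmoved within the scatter. Compound 2 therefore stands level with compound 1 at the digits printed, at the bottom of the read-out.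

Compound 3, `COc1ccc([C@@]2(CO)NC[C@H](O)[C@H]2O)cc1OC`, is the next member. It differs from compound 2 as follows: methoxy in place of hydrogen on an aromatic carbon. Within the data shown here, the only step that bears on this is the one from compound 1 to compound 2, a change of aromatic substituent that produced no movement beyond the scatter. No measured change on this ring has shifted the read-out. For compound 3 the expected step is no change at the digits printed from compound 2 to compound 3 (within the scatter), that is none beyond the scatter. The estimate for compound 3 is 0%, with a range from 0% to 10%.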

Compound 3, a percentage reported as inhibition, at one concentration (the size of the read-out at that concentration, not a potency): 0%
Compound 3: middle estimate and measured number agree at the digits printed; low and high end bracket the measured number.
By their numbers in this assay, from the lowest: compounds 1, 2 and 3 (each within the scatter of the next).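

In this assay, the step reads no change at the digits printed from compound 2 to compound 3 (within the scatter): a methoxy placed on an aromatic carbon ortho to a methoxy group and para to a group of 9 heavy atoms leaves the read-out unmoved. The earlier step only exchanged one substituent for another, whereas this one adds a group where hydrogen stood, and compound 3 still gives 0%. Nothing available explains this flat result.

With every compound shown at the bottom of the read-out, these steps cannot tell whether substitution on this ring matters when inhibition is present. Still open, as far as these compounds go, is whether an amine or a carboxylic acid on the aromatic ring, or a longer chain in place of the methoxy, would give any measurable inhibition in this assay.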